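A few compounds are considered here, and "the series" means these few. Any claim that something is new, unique, unknown or untested is made for them only; others in the source may bear on it.

Compound 1 `Cn1c(-c2ccc(NC(=O)CSc3nc4ccccc4o3)cc2)nc(-c2ccccc2)c1-c1ccccc1`: 81.5%
Compound 2 `Cc1nnc(SCC(=O)Nc2ccc(-c3nc(-c4ccccc4)c(-c4ccccc4)n3C)cc2)s1`: 90.5%
Compound 3 `Cn1ccnc1SCC(=O)Nc1ccc(-c2nc(-c3ccccc3)c(-c3ccccc3)n2C)cc1`: 69.4%

These three compounds share one core and differ only in the aromatic ring attached to a sulfur. In a functional assay on HT-29 cells (Homo sapiens) for cytotoxicity, read by MTT assay, with a stated time of 24 h, tested at 80 ug/mL (on this read-out lower numbers stand for a weaker effect and higher numbers for a stronger effect at the one concentration tested), compound 2 gives the highest of the three numbers, but the step of a number 9 percentage points higher from compound 1 to compound 2 (within the scatter) lies within the scatter, so compound 2 and compound 1 cannot be told apart. The steps of a number 21.1 percentage points lower from compound 2 to compound 3 (beyond the scatter) and a number 12.1 percentage points lower from compound 1 to compound 3 (beyond the scatter) lie beyond the scatter, so compound 3 is the one that stands apart, with the weaker effect.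

Compound 4 `CN(C)/C=C/N1CCN(CC(=O)Nc2ccc(-c3nc(-c4ccccc4)c(-c4ccccc4)n3C)cc2)CC1` has not yet been measured. It differs from compound 2 in this way: 4-(2-(dimethylamino)ethenyl)piperazin-1-yl in place of (5-methyl-1,3,4-thiadiazol-2-yl)sulfanyl on a saturated chain carbon bound to a carbonyl carbon. The measured steps only exchange one aromatic ring while the sulfur stays in place; none removes the sulfanyl link or brings in a six-membered non-aromatic ring, so they bear on this change only loosely. Within the data shown here, the one precedent is that leaving the 5-methyl-1,3,4-thiadiazol-2-yl group of compound 2 gave a number 21.1 percentage points lower from compound 2 to compound 3 (beyond the scatter), a downward step. A change this large, with so little precedent, calls for a wide range. Compound 4 is therefore expected to give 60%, somewhere between 35% and 85%. This estimate means a step of a number 30.5 percentage points lower from compound 2 to compound 4 (beyond the scatter), expected to run downward and beyond the scatter.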

Compound 4, a percentage reported as activity, at one concentration (the size of the read-out at that concentration, not a potency): 45.4%
Compound 4: middle estimate off by 14.6 percentage points, on the high side; low and high end bracket the measured number.
By their numbers in this assay, from the lowest: compound 4; then compound 3; then compounds 1 and 2 (each within the scatter of the next).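

In this assay, putting 4-(2-(dimethylamino)ethenyl)piperazin-1-yl on the saturated chain carbon bound to a carbonyl carbon gives a number 45.1 percentage points lower from compound 2 to compound 4 (beyond the scatter) and a number 36.1 percentage points lower from compound 1 to compound 4 (beyond the scatter) and also a number 24 percentage points lower from compound 3 to compound 4 (beyond the scatter) in place of the sulfanyl-linked rings. The earlier compounds shown here only exchanged one aromatic ring on the sulfur, whereas these steps show that removing the sulfanyl link and its ring together lowers the number from all three starting points, beyond the scatter each time, and that compound 4 still gives 45.4% at the one concentration tested. Nothing measured here explains this fall.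

On these data alone, the sulfur, the aromatic ring, the piperazine ring and the dimethylamino ethenyl arm all change at once, so the part responsible stays open. A plain piperazin-1-yl or a morpholin-4-yl group on the same carbon would help separate these parts.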